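Fluoro for Bromo on a Weakly Cytotoxic Scaffold

A few compounds are considered here, and "the series" means these few. Any claim that something is new, unique, unknown or untested is made for them only; others in the source may bear on it.

Of the compounds shown here, two built on one shared core have been tested in a functional assay on MCF7 cells (Homo sapiens) for cytotoxicity, read by MTT assay, with a stated time of 4 days; on this read-out lower numbers stand for stronger inhibition and higher numbers for weaker inhibition. Compound 1 `C=C1C(=O)[C@]23C[C@@]1(O)CC[C@H]2c1ccc(O)c(C)c1[C@@H]3Cn1cc(-c2ccccn2)nn1` gives 2240 nM. Compound 2 `C=C1C[C@]23C[C@@]1(O)CC[C@H]2c1ccc(O)c(C)c1[C@@H]3Cn1cc(-c2ccc(Br)cc2)nn1`, which carries a 4-bromophenyl group, reaches only the limit of the assay, > 20000 nM, so its true potency is not known as a number. Compound 2 therefore stands at the limit of > 20000 nM in this assay, at which 1 of the 2 values shown sits. Compound 3 `C=C1C[C@]23C[C@@]1(O)CC[C@H]2c1ccc(O)c(C)c1[C@@H]3Cn1cc(-c2ccc(F)cc2)nn1` differs from compound 2 by a single change, fluoro in place of bromo on an aromatic carbon. Among the compounds with values here, no measured pair shows this exact swap, so the size of the step cannot be read from the data. Since compound 2 gives > 20000 nM, compound 3 is expected to be weak as well, estimated near 15000 nM with a range from 4000 nM to 40000 nM, and quite possibly reported again as a limit. The expected step is an at least 1.3-fold lower number from compound 2 to compound 3 (0.12 log units; that floor lies within the scatter), leaning toward stronger inhibition but likely within the scatter.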

Compound 3, half-maximal inhibitory concentration: > 20000 nM
Compound 3 ended at the assay's limit; the forecaster's own chance of this, stated with the estimate: 50%; middle value at least 1.3-fold (0.12 log units) away from the limit.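

Within the data shown here, compound 2 and compound 3 both end at a limit rather than a number, so no step between them can be read in this assay: the limit of > 20000 nM in this assay, at which 2 of the 3 values shown sit. Still open, from the compounds shown here alone, is whether fluoro in place of bromo changes cytotoxicity at all, and how far either compound lies beyond that limit.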